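The source may hold more compounds than are shown below. What is called first, only, known or untested is meant among the compounds shown, and "the series" means these compounds.

Measured in a functional assay on HeLa cells (Homo sapiens) for antiproliferative activity, read by cell counting, with a stated time of 72 h; on this read-out higher numbers stand for weaker inhibition and lower numbers for stronger inhibition:
- Compound 1 `C#C[C@@]1(O)[C@@H](CO)O[C@@H](n2cnc3c(-c4ccccc4)ncnc32)[C@@H]1O`: > 250000 nM, a limit
- Compound 2 `C#C[C@@]1(O)[C@@H](CO)O[C@@H](n2cnc3c(-c4ccc(C)cc4)ncnc32)[C@@H]1O`: > 250000 nM, a limit
- Compound 3 `C#C[C@@]1(O)[C@@H](CO)O[C@@H](n2cc(Br)c3c(N)ncnc32)[C@@H]1O`: 93 nM

Going by the values given here, compound 3 gives 93 nM, the only actual number in this set. Compound 4 `C#C[C@@]1(O)[C@@H](CO)O[C@@H](n2cc(C(F)(F)F)c3c(N)ncnc32)[C@@H]1O` carries trifluoromethyl in place of bromo on an aromatic carbon, (trifluoromethyl in place of bromo on an aromatic carbon). That carbon belongs to a five-membered aromatic ring with 1 nitrogen, part of a fused system of two rings.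

Among the compounds with values here, only one measured step is available, a step that the two limits leave unreadable from compound 1 to compound 2, and it is a methyl in place of hydrogen on an aromatic carbon. Within the data shown here, it gives no size to carry over, and no measured step tests a change at the carbon that differs in compound 4. Among the measured compounds shown here, the only further guide is the limit of > 250000 nM in this assay, at which 2 of the 3 values shown sit, which shows how far the read-out can fall. The expectation is therefore a modest step with wide uncertainty, leaning toward weaker inhibition in this assay. The expected step is a 2.7-fold higher number from compound 3 to compound 4 (0.43 log units; beyond the scatter). The estimated value for compound 4 is 250 nM, with an expected range of 40 nM to 2500 nM.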

Compound 4, half-maximal inhibitory concentration: 750 nM
For compound 4 the middle estimate is 3.0-fold (0.48 log units) below the measured one; measured number inside the range.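

In this assay, trifluoromethyl in place of bromo on this aromatic carbon gives the set its first readable step, an 8.1-fold higher number from compound 3 to compound 4 (0.91 log units; beyond the scatter) and thereby shows that this position responds to the change; the earlier step, methyl in place of hydrogen on an aromatic carbon, cannot be read, as both of its values are limits. Even with four heavy atoms entering where one leaves, compound 4 gives 750 nM as an actual number and not a limit. Nothing measured here bears on why the step has this size.

On these data alone, it remains open whether chloro, a nitrile or an amine on this carbon would give a value nearer to that of compound 3 or to that of compound 4. As far as these compounds go, it also remains open whether the same replacement would give a similar step on a different core.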